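Shortening the chain in the selenium series

A few compounds are considered here, and "the series" means these few. Any claim that something is new, unique, unknown or untested is made for them only; others in the source may bear on it.

In a functional assay on LoVo cells (Homo sapiens) for inhibition, read by MTT assay, with a stated time of 48 h (a lower number here means a stronger inhibitor, a higher number a weaker inhibitor), compound 1 `COc1ccc(N(C)c2nc(C)nc3ccccc23)cc1OCCCCCC[Se]C#N` gives 8580 nM and compound 2 `COc1ccc(N(C)c2nc(C)nc3ccccc23)cc1OCCCC[Se]C#N` gives 882 nM, the lower of the two numbers. Compound 3 `COc1ccc(N(C)c2nc(C)nc3ccccc23)cc1[Se]C#N` carries a group of 3 heavy atoms (1 carbon, 1 nitrogen, 1 selenium; no ring) in place of a group of 8 heavy atoms (5 carbon, 1 nitrogen, 1 oxygen, 1 selenium; no ring), on an aromatic carbon, on an aromatic carbon, ortho to a methoxy group. Going by the values given here, the only measured step that bears on this is a 9.7-fold lower number from compound 1 to compound 2 (0.99 log units; beyond the scatter), a shortening of the chain. Among the compounds with values here, that step points to a further fall, but no measured compound has the group directly on the aromatic carbon, so the size is uncertain. The expected change is a 2.9-fold lower number from compound 2 to compound 3 (0.47 log units; beyond the scatter), a modest one. For compound 3 the estimated value is 300 nM, with a range of 40 nM to 3000 nM.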

Compound 3, half-maximal inhibitory concentration: 73 nM
Beside the measured number, compound 3's estimate is 4.1-fold (0.61 log units) above it, and the stated range covers the measured number.
By their numbers in this assay, from the lowest: compound 3; then compound 2; then compound 1.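

With the chain and its oxygen gone, the group of 3 heavy atoms sits on the aromatic carbon itself, and this assay shows a 12-fold lower number from compound 2 to compound 3 (1.08 log units; beyond the scatter). The series end to end gives a 120-fold lower number from compound 1 to compound 3 (2.07 log units; beyond the scatter), so the number falls with each shortening in these compounds, and none goes against this. No data at hand explain the fall.

Open, on these data alone, is whether selenium is needed at this position: a plain nitrile or a sulfur-linked nitrile on that aromatic carbon would test it. A two-carbon chain would show how the fall proceeds between the chain of compound 2 and the direct attachment of compound 3.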